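Replacing the (piperidin-1-yl)carbonyl group of compound 1

The source may report more compounds than this note shows. Statements on the series, on what has been measured and on what is new or still open speak of the compounds shown alone.

For the measured compounds named here, in a functional assay on a cell-free system (Platelet, plasma, Homo sapiens) for inhibition, read by turbidimetry, with a stated time of 3 min (on this read-out lower numbers stand for stronger inhibition and higher numbers for weaker inhibition), compound 1 (`COc1ccc(-n2nc(C(=O)N3CCCCC3)cc2-c2ccc(Cl)cc2)nn1`) gives 41 nM as the lowest of the three numbers so far. Compound 4 (`COc1ccc(-n2nc(CCC(=O)N3CCOCC3)cc2-c2ccc(Cl)cc2)nn1`) is still unmeasured. It carries 2-((morpholin-4-yl)carbonyl)ethyl in place of (piperidin-1-yl)carbonyl on an aromatic carbon. Going by the values given here, only one step between measured compounds can be read directly (a 51-fold higher number from compound 1 to compound 3 (1.71 log units; beyond the scatter)), and it is large. It leads to compound 3 (`O=C(c1cc(-c2ccc(Cl)cc2)n(-c2ccc(=O)[nH]n2)n1)N1CCCCC1`), which gives 2090 nM but differs on an aromatic nitrogen, not on this carbon. Among the compounds with values here, that step shows only that the numbers can move sharply on a small change. Closer to the present change is compound 2 (`COc1ccc(-n2nc(C(=O)N3CCN(c4ccc(C(F)(F)F)cn4)CC3)cc2-c2ccc(Cl)cc2)nn1`), which holds another group on that aromatic carbon and gives 5490 nM in a far higher range than compound 1 does. Within the data shown here, a rise beyond the scatter is therefore expected in this assay although no measured step fixes its size. The expected step is a 20-fold higher number from compound 1 to compound 4 (1.29 log units; beyond the scatter) on this reasoning. The estimate for compound 4 is 800 nM with an expected range from 150 nM to 4000 nM in this measurement.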

Compound 4, half-maximal inhibitory concentration: 1080 nM
For compound 4 the middle estimate is 1.4-fold (0.13 log units) below the measured one; the range from low to high includes it.
By their numbers in this assay, from the lowest: compound 1; then compounds 4 and 3 (each within the scatter of the next); then compound 2.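

For the compounds shown here, this is the first step read directly at this aromatic carbon: in this assay, a 26-fold higher number from compound 1 to compound 4 (1.42 log units; beyond the scatter), so replacing (piperidin-1-yl)carbonyl with 2-((morpholin-4-yl)carbonyl)ethyl costs a large rise, and compound 1 keeps the lowest number. The entering group differs in two ways at once, since it has a chain between the carbonyl and the aromatic carbon and a ring with one more hetero atom, so this single step cannot divide the rise between them. Nothing measured here explains the rise.

Still open, from the compounds shown here alone, is where (morpholin-4-yl)carbonyl or 2-((piperidin-1-yl)carbonyl)ethyl on this carbon would fall, as either would separate the effect of the ring from that of the chain. Also open, going by these compounds, is how a carboxylic acid or an amine at this position would read out.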